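The compounds below may be only part of what the source reports. "The series", "measured", "known", "first", "only" and "open" are said of these compounds alone.

Measured so far:
- compound 1 `CCCCCCCC/C=C/CCCCCCCC(=O)O[C@H]1[C@H](O)[C@H](n2ccc(N)nc2=O)O[C@@H]1CO`: 0.05 ug/mL
- compound 2 `CCCCCCC/C=C\C(=O)O[C@H]1[C@H](O)[C@H](n2ccc(N)nc2=O)O[C@@H]1CO`: 0.06 ug/mL
- compound 3 `CCCCCCCC/C=C\CCCCCCCCCCCC(=O)O[C@H]1[C@H](O)[C@H](n2ccc(N)nc2=O)O[C@@H]1CO`: 0.16 ug/mL

All three values come from a functional assay on HeLa cells (Homo sapiens) for cytotoxicity, read by cell counting, with a stated time of 48 h; on this read-out lower numbers stand for an effect already at smaller amounts and higher numbers for an effect only at larger amounts of compound. On these numbers compound 3 stands highest of the three: compound 2 lies nearest with a lower number, compound 1 furthest with a lower number still, and both of those gaps fall beyond the scatter. Compound 3 is therefore the compound with the weakest effect among the three measured.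

Compound 4 `CCCCCCCCCCCCCCCCCCCC(=O)O[C@H]1[C@H](O)[C@H](n2ccc(N)nc2=O)O[C@@H]1CO` is not yet measured. Against compound 3 it shows one difference, (octyl in place of dec-1-en-1-yl on a saturated chain carbon, ten or more bonds along the chain from a carbonyl carbon). The ester-bearing sugar and base part of the shared core is untouched; the change sits far out along the acyl chain.

Among the measured compounds shown here, no pair of measured compounds differs in one place, so no measured step gives a direct guide. The acyl chains of compound 1, compound 2 and compound 3 span a wide range of length and unsaturation with a modest spread of values, so the expected step of a 1.1-fold lower number from compound 3 to compound 4 (0.03 log units; within the scatter) is small, without clear direction, and likely within the scatter in this assay. Compound 4 is estimated at 0.15 ug/mL, with a range from 0.05 ug/mL to 0.5 ug/mL.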

Compound 4, concentration for half-maximal effect: 0.1 ug/mL
Beside the measured number, compound 4's estimate is 1.5-fold (0.18 log units) above it, within the range that was stated.
By their numbers in this assay, from the lowest: compounds 1, 2, 4 and 3 (each within the scatter of the next, the first and the last beyond it).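

In this assay, among the compounds shown here, a 1.6-fold lower number from compound 3 to compound 4 (0.20 log units; within the scatter) gives the first one-place step at this position, and octyl in place of dec-1-en-1-yl, on a saturated chain carbon, leaves the two compounds indistinguishable. The second step, a 2.0-fold higher number from compound 1 to compound 4 (0.30 log units; within the scatter), also stays within the scatter, this time on a saturated chain carbon seven bonds along the chain from a carbonyl carbon. Compound 4 carries a fully saturated acyl chain, so on these two steps a double bond in the chain is not needed for an effect at this level in this series.

The data at hand give no reason for these values. Still open, from the compounds shown here alone, is how this assay would respond to a much shorter saturated chain, or to a chain carrying a carboxylic acid or an amine.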